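Cytotoxicity notes: chain methyl added on the shared core

The source may hold more compounds than are shown below. What is called first, only, known or untested is meant among the compounds shown, and "the series" means these compounds.

Compound 1, `COc1ccc(CSc2nc(Cc3cc(C)cc(C)c3)c(C)c(=O)[nH]2)cc1`: in an ADME assay on MT4 cells (Homo sapiens) for cytotoxicity, read by MTT assay (on this read-out lower numbers stand for higher toxicity in this test and higher numbers for lower toxicity in this test), compound 1 gives > 329000 nM, a limit of the assay.
Compound 2, `Cc1cc(C)cc(Cc2nc(SCc3ccc([N+](=O)[O-])cc3)[nH]c(=O)c2C)c1`: in this assay compound 2 gives > 316000 nM, again a limit of the assay.

For the measured compounds named here, compound 2 therefore stands at a limit, and the only other value shown is also a limit. The step from compound 1 to compound 2, nitro in place of methoxy on an aromatic carbon, reads as a step that the two limits leave unreadable from compound 1 to compound 2; this follows from the limit of > 316000 nM in this assay, at which 1 of the 2 values shown sits, and (the limit of > 329000 nM in this assay, at which 1 of the 2 values shown sits).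

Compound 3, `CCc1c(Cc2cc(C)cc(C)c2)nc(SCc2ccc([N+](=O)[O-])cc2)[nH]c1=O`, differs from compound 2 by methyl in place of hydrogen on a saturated chain carbon bound to an aromatic carbon. Going by the values given here, no measured step touches this chain position, and the one measured step is unreadable, so nothing quantitative bears on the change. Without evidence of toxicity anywhere in the series, no step beyond the scatter is expected in this assay, in either direction; the step from compound 2 to compound 3 is estimated as a number no higher from compound 2 to compound 3 (the limit leaves the size open). Compound 3 is expected to give about 316000 nM in this assay, within 150000 nM to 500000 nM, most likely reported only as a limit.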

Compound 3, half-maximal cytotoxic concentration: > 305000 nM
Compound 3 was reported as a limit; the forecaster's own chance of this, stated with the estimate: 80%; the middle value lies beyond the limit too.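

In this assay compound 3 gives > 305000 nM, a limit of the assay. For the compounds shown here, compound 2 gives > 316000 nM, also a limit, so no step between compound 2 and compound 3 can be read. The compounds shown leave open at what concentration any of them becomes cytotoxic, and whether the added methyl changes that.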